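Acetyl Replacing Methoxy in Weak Phospholipase Inhibitors

This account rests on a few compounds, and the source may have more. Where it says the series, first, only, none or still open, it means among the compounds named here.

Of the compounds shown here, two have so far been tested in an assay on COS-7 cells for inhibition of patatin-like phospholipase domain-containing protein 2 (Mus musculus); a higher number here means a weaker inhibitor, a lower number a stronger inhibitor. In this assay compound 1, with the structure `CCOC(=O)c1ccc(-c2ccc(OCC)cc2)s1`, gives 70000 nM. Compound 2, with the structure `CCOC(=O)c1cccc(-c2ccc(OC)cc2)c1`, gives 80000 nM in this assay. For the measured compounds named here, compound 2 thus holds the highest of the two numbers, yet its only neighbour, compound 1, sits within the scatter of it, so the two cannot be placed in order; both are weak inhibitors. Going by the values given here, no pair of measured compounds differs in just one place, so no measured step is available to guide expectations.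

The next compound, compound 3 with the structure `CCOC(=O)c1cccc(-c2ccc(C(C)=O)cc2)c1`, differs from compound 2 by a single exchange: acetyl in place of methoxy on an aromatic carbon. Among the compounds with values here, nothing among the measured compounds shows how such an exchange shifts the number in this assay. The step of a 1.3-fold lower number from compound 2 to compound 3 (0.12 log units; within the scatter) is therefore expected to be modest, in no firm direction, and quite possibly within the scatter. Compound 3 is estimated at 60000 nM, with a range from 15000 nM to 200000 nM.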

Compound 3, half-maximal inhibitory concentration: 200000 nM
Beside the measured number, compound 3's estimate is 3.3-fold (0.52 log units) below it; measured number inside the range.
By their numbers in this assay, from the lowest: compounds 1 and 2 (each within the scatter of the next); then compound 3.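

For the compounds shown here, this is the first measured exchange at this position, on an aromatic carbon of a six-membered aromatic ring of carbon only, para to a large group. In this assay, acetyl in place of methoxy gives a 2.5-fold higher number from compound 2 to compound 3 (0.40 log units; beyond the scatter), a modest weakening of inhibition that lies beyond the scatter, so the number does respond to what is placed here, even though the two groups have the same counts of hydrogen-bond donors and acceptors and differ in acetyl's extra carbon and its double bond outside the aromatic ring. No measurement shown bears on why the number rises, and this single exchange cannot say which difference between the groups matters.

Going by these compounds, whether an amine, a carboxylic acid or a longer alkoxy chain at this position would lower the number or raise it further remains open, as does whether any group here can lift these compounds out of their weak range. Compound 1 differs from compound 2 in more than one place, so it also leaves open whether the same exchange would have a similar effect on the core of compound 1.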